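This account rests on a few compounds, and the source may have more. Where it says the series, first, only, none or still open, it means among the compounds named here.

In a functional assay on HepG2 cells (Homo sapiens) for antiproliferative activity, read by XTT assay, with a stated time of 72 h (on this read-out lower numbers stand for stronger inhibition and higher numbers for weaker inhibition), compound 1 (`C#Cc1cn([C@@H]2O[C@H](CO)[C@@H](O)[C@H]2O)c2ncnc(N(C)C)c12`) gives 1320 nM. Compound 2 (`Nc1nc(N)c2c(-c3ccco3)cn([C@@H]3O[C@H](CO)[C@@H](O)[C@H]3O)c2n1`) reads > 20000 nM, which is a limit and not a number. Compound 3 (`Cc1nc(N)c2c(-c3ccco3)cn([C@@H]3O[C@H](CO)[C@@H](O)[C@H]3O)c2n1`) reads > 20000 nM, likewise only a limit, and so stands at the limit of > 20000 nM in this assay, at which 2 of the 3 values shown sit. Compound 4 (`Cc1nc(N)c2c(I)cn([C@@H]3O[C@H](CO)[C@@H](O)[C@H]3O)c2n1`) carries iodo in place of furan-2-yl on an aromatic carbon. Among the measured compounds shown here, the only measured step, a step that the two limits leave unreadable from compound 2 to compound 3, is a different exchange and gives no size to carry over. For the measured compounds named here, no measured step covers this exchange, so only a cautious expectation is possible: a modest gain in this assay, or none. The expected change is an at least 1.6-fold lower number from compound 3 to compound 4 (0.22 log units; that floor lies within the scatter). For compound 4 the estimate is 12000 nM, with an expected range of 2000 nM to 40000 nM.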

Compound 4, half-maximal inhibitory concentration: 6310 nM
Beside the measured number, compound 4's estimate is 1.9-fold (0.28 log units) above it; measured number inside the range.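

At this position, on an aromatic carbon two ring bonds from the ring nitrogen, the exchange of furan-2-yl for iodo gives the only readable step among these close pairs in this assay: an at least 3.1-fold lower number from compound 3 to compound 4 (0.50 log units; beyond the scatter). The group here therefore moves the read-out, and iodo brings a measured number to a compound pair that otherwise ends at a limit. That step is only a floor, since compound 3 reads a limit and not a number: the limit of > 20000 nM in this assay, at which 2 of the 4 values shown sit.

From the compounds shown here alone, whether other groups on this carbon do better than iodo stays open, for instance a nitrile or an ethyl chain. Also open, going by these compounds, is whether amino in place of methyl on the shared core would shift the iodo compound.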